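The compounds below may be only part of what the source reports. "The series", "measured", "known", "first", "only" and "open" are said of these compounds alone.

Measured so far in a functional assay on CHO-K1 cells for agonist activity at Glucose-dependent insulinotropic receptor (Homo sapiens), read by a luciferase reporter, with a stated time of 5 h; on this read-out lower numbers stand for an effect already at smaller amounts and higher numbers for an effect only at larger amounts of compound: compound 1 `CC(C)OC(=O)N1CCC(COc2ccc(N3CCN(C(=O)N(C)C)CC3)nc2)CC1` gives a limit of > 10000 nM. Compound 2 `CCCCS(=O)(=O)N1CCN(c2ccc(OCC3CCN(C(=O)OC(C)C)CC3)cn2)CC1` gives 100 nM. Compound 3 `CCCS(=O)(=O)N1CCN(c2ccc(OCC3CCN(C(=O)NC(C)C)CC3)cn2)CC1` gives 1000 nM.

Compound 3 stands highest of the two numbers, with compound 2 nearest at a clearly lower value; the third value is only a limit, as the reading for compound 1 sits at the assay's upper bound (the limit of > 10000 nM in this assay, at which 1 of the 3 values shown sits). Among the measured compounds shown here, the one measured single-point step, an at least 100-fold lower number from compound 1 to compound 2 (2.00 log units; beyond the scatter), concerns a different position and so does not bear directly on the change now considered, which is furan-2-yl in place of isopropylamino on a carbonyl carbon, giving compound 4 `CCCS(=O)(=O)N1CCN(c2ccc(OCC3CCN(C(=O)c4ccco4)CC3)cn2)CC1`. Compounds 2 and 3 differ in two places at once, so their values alone cannot separate the contribution of the carbonyl substituent. For the measured compounds named here, with no measured step on this position, compound 4 is expected to stay close to compound 3, at an estimated 800 nM (range 150 nM to 4000 nM), a step of a 1.3-fold lower number from compound 3 to compound 4 (0.10 log units; within the scatter) that is expected to lie within the scatter.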

Compound 4, half-maximal effective concentration: 2000 nM
Beside the measured number, compound 4's estimate is 2.5-fold (0.40 log units) below it, within the range that was stated.
By their numbers in this assay, from the lowest: compound 2; then compounds 3 and 4 (each within the scatter of the next). At a limit, above all of these: compound 1.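

In this assay, furan-2-yl in place of isopropylamino on the carbonyl carbon gives a 2.0-fold higher number from compound 3 to compound 4 (0.30 log units; within the scatter), the first step measured at this position. The hydrogen-bond donor of isopropylamino leaves and a five-membered aromatic ring enters, and the read-out stays within the scatter, so this pair gives no sign that the donor is required. No measured evidence here accounts for this outcome.

Open, going by these compounds, is how a phenyl or thiophen-2-yl group on this carbonyl carbon would read. Also open, on these data alone, is how isopropoxy there would read with the propylsulfonyl group of compound 4.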